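Changing One Ring Atom in a Level Series

A few compounds are considered here, and "the series" means these few. Any claim that something is new, unique, unknown or untested is made for them only; others in the source may bear on it.

Of the compounds shown here, three that share one core have been tested in a functional assay on HepG2 cells (Homo sapiens) for antiproliferative activity, read by CCK-8 assay, with a stated time of 72 h; a higher number here means a weaker inhibitor, a lower number a stronger inhibitor. Compound 1 (`Nc1ccccc1NC(=O)c1ccc(Cn2cnc3c(Nc4ccccc4)nc(Cl)nc32)cc1`) gives 4180 nM, compound 2 (`Nc1ccccc1NC(=O)c1ccc(Cn2cnc3c(NCc4ccccc4)nc(Cl)nc32)cc1`) gives 7720 nM, and compound 3 (`CC1CCN(c2nc(Cl)nc3c2ncn3Cc2ccc(C(=O)Nc3ccccc3N)cc2)CC1`) gives 5180 nM. The value of compound 3 lies within the scatter of both others.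

Compound 4 (`CN1CCN(c2nc(Cl)nc3c2ncn3Cc2ccc(C(=O)Nc3ccccc3N)cc2)CC1`) has not yet been measured. It carries 4-methylpiperazin-1-yl in place of 4-methylpiperidin-1-yl on the same aromatic carbon: 4-methylpiperazin-1-yl in place of 4-methylpiperidin-1-yl on an aromatic carbon.

For the measured compounds named here, no measured step tests this exact swap. The closest evidence comes from that same carbon, where much larger exchanges gave only a 1.2-fold higher number from compound 1 to compound 3 (0.09 log units; within the scatter) and a 1.5-fold lower number from compound 2 to compound 3 (0.17 log units; within the scatter). Among these three compounds, then, changing the group there has not moved the number beyond the scatter. The same is expected here, with no real shift in either direction in this assay. The expected step is a 1.0-fold lower number from compound 3 to compound 4 (0.02 log units; within the scatter). Compound 4 is estimated at 5000 nM, with an expected range from 2200 nM to 11500 nM.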

Compound 4, half-maximal inhibitory concentration: 2010 nM
Estimate against measurement, compound 4: 2.5-fold (0.40 log units) above, and the stated range ends above it.
By their numbers in this assay, from the lowest: compound 4; then compounds 1, 3 and 2 (each within the scatter of the next).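

Swapping a single ring atom at this carbon, 4-methylpiperazin-1-yl in place of 4-methylpiperidin-1-yl with the same count of heavy atoms, gives a 2.6-fold lower number from compound 3 to compound 4 (0.41 log units; beyond the scatter) in this assay, the first step here to pass beyond the scatter. Compound 4 also separates from the anilino and benzylamino compounds, with a 2.1-fold lower number from compound 1 to compound 4 (0.32 log units; beyond the scatter) and a 3.8-fold lower number from compound 2 to compound 4 (0.58 log units; beyond the scatter), so a position that seemed indifferent among compounds 1, 2 and 3 does respond to change, though only modestly. Nothing available here accounts for this difference.

The compounds shown leave open whether the step depends on the second ring nitrogen or on the methyl group it carries. A morpholin-4-yl ring, with an oxygen in that place, and an unsubstituted piperazin-1-yl ring would help separate these two possibilities.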